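Removing the Methyl from the Sulfonyl Aryl Ring

The compounds below may be only part of what the source reports. "The series", "measured", "known", "first", "only" and "open" are said of these compounds alone.

Measured compounds:
compound 1 `Cc1ccc(C(=O)NCc2ccc(CNS(=O)(=O)c3ccc(C)cc3)cc2)cc1` — 1000 nM
compound 2 `Cc1ccc(S(=O)(=O)NCc2ccc(CNC(=O)c3c(Cl)cc(Cl)cc3Cl)cc2)cc1` — 10 nM
compound 3 `Cc1ccc(S(=O)(=O)NCc2ccc(CNC(=O)c3ccccc3)cc2)cc1` — > 1000 nM

In an assay on MDA-MB-231 cells for binding affinity to C-X-C chemokine receptor type 4 (Homo sapiens), read by immunofluorescence and microscopy, with stated times of 10 min and 30 min (a lower number here means that less compound is needed, a higher number that more compound is needed for the effect), compound 1 gives 1000 nM. Compound 2 gives 10 nM and so stands lowest of the two numbers, with a 100-fold lower number from compound 1 to compound 2 (2.00 log units; beyond the scatter) as the step that separates them. For compound 3 the assay reports only a limit, (the limit of > 1000 nM in this assay, at which 1 of the 3 values shown sits). The step of an at least 100-fold higher number from compound 2 to compound 3 (2.00 log units; beyond the scatter) is therefore read as large, while a number no lower from compound 1 to compound 3 (the limit leaves the size open) cannot be sized.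

Compound 4 `O=C(NCc1ccc(CNS(=O)(=O)c2ccccc2)cc1)c1c(Cl)cc(Cl)cc1Cl` follows compound 2 by hydrogen in place of methyl on an aromatic carbon. Within the data shown here, the only measured step of the same kind is that from compound 1 to compound 3, and its size is not readable from a limit. Among the measured compounds shown here, no measured step shows this change on a 2,4,6-trichlorophenyl amide, so the expectation rests on the one unreadable precedent. Compound 4 is expected to give about 15 nM, between 5 nM and 60 nM. This estimate means a step of a 1.5-fold higher number from compound 2 to compound 4 (0.18 log units; within the scatter), expected to stay within the scatter.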

Compound 4, effective concentration (reported as EC, without a stated level of effect): 10 nM
For compound 4 the middle estimate is 1.5-fold (0.18 log units) above the measured one, within the range that was stated.
By their numbers in this assay, from the lowest: compounds 2 and 4 (each within the scatter of the next); then compound 1.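

In this assay, among these compounds, the change from 4-methylphenyl to phenyl can now be read for the first time, with no change at the digits printed from compound 2 to compound 4 (within the scatter). Compound 4, which lacks the methyl, gives 10 nM, so on the core bearing the 2,4,6-trichlorophenyl amide the methyl is not required for a number of this size. The same change on the other core cannot be read, so the compounds cannot show whether the two cores respond alike: the same change on two cores in this assay, a number no lower (the limit leaves the size open) from compound 1 to compound 3 and no change at the digits printed (within the scatter) from compound 2 to compound 4; the limit leaves it open whether they differ

The compounds shown carry only methyl or hydrogen on this aromatic carbon, so it remains open how a methoxy group, an amine or a carboxylic acid there would read. Going by these compounds, it also remains open whether a longer chain, such as propyl, would be accepted at this place on the same core.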